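A few compounds are considered here, and "the series" means these few. Any claim that something is new, unique, unknown or untested is made for them only; others in the source may bear on it.

Measured so far:
compound 1 `CC(=O)Nc1ccc(S(=O)(=O)NNc2ccc(Cl)c(Cl)c2)cc1` — 350 nM
compound 2 `O=S(=O)(NNc1ccc(Br)cc1)c1ccc(Br)cc1` — 374 nM
compound 3 `N#Cc1ccc(S(=O)(=O)NNc2ccc(Br)cc2)cc1` — 134 nM

In an assay on HeLa cells for inhibition of Indoleamine 2,3-dioxygenase 1 (Homo sapiens), read by spectrophotometry, with a stated time of 24 h (on this read-out higher numbers stand for an effect only at larger amounts of compound and lower numbers for an effect already at smaller amounts), compound 3 gives the lowest number of the three measured compounds, and its gap to compound 1 and to compound 2 is in each case beyond the usual scatter. Compound 4 `O=C(O)COc1ccc(S(=O)(=O)NNc2ccc(Br)cc2)cc1` differs from compound 3 in one place: carboxymethoxy in place of cyano on an aromatic carbon. Among the compounds with values here, the only measured step that touches this position is a 2.8-fold lower number from compound 2 to compound 3 (0.45 log units; beyond the scatter), where the cyano group replaced a bromo group. Within the data shown here, no measured step shows what a carboxymethoxy group does at this position, so the expectation rests on the fact that the cyano group, which is now removed, was the one change that lowered the number. Its removal is therefore expected to give back some or all of that gain, so the estimate for compound 4 is a modest rise, a 3.0-fold higher number from compound 3 to compound 4 (0.47 log units; beyond the scatter), with wide uncertainty. The estimated value for compound 4 is 400 nM, within a range from 130 nM to 1200 nM.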

Compound 4, half-maximal effective concentration: 152 nM
Compound 4: the middle estimate sits 2.6-fold (0.42 log units) above what was measured, within the range that was stated.
By their numbers in this assay, from the lowest: compounds 3 and 4 (each within the scatter of the next); then compounds 1 and 2 (each within the scatter of the next).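

In this assay, carboxymethoxy in place of cyano on this aromatic carbon, para to a large group, gives a 1.1-fold higher number from compound 3 to compound 4 (0.05 log units; within the scatter) even though the entering group has 5 heavy atoms against 2 for the one leaving, so this position accepts the larger group without a change beyond the scatter. Among these compounds, the lower number relative to the bromo compound therefore does not depend on the cyano group alone: carboxymethoxy in place of bromo gives a 2.5-fold lower number from compound 2 to compound 4 (0.39 log units; beyond the scatter) in the same way that cyano in place of bromo gave a 2.8-fold lower number from compound 2 to compound 3 (0.45 log units; beyond the scatter) on this read-out. No measured evidence here explains why these two different groups read alike.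

As far as these compounds go, it remains open which part of the carboxymethoxy group matters, and a methoxy group or a carboxylic acid on the ring would test this. An amine or a longer chain ending in a carboxylic acid at this position would show how far this tolerance extends.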